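Swapping the hydroxy-heteroaryl ring on a shared amide

The source may hold more compounds than are shown below. What is called first, only, known or untested is meant among the compounds shown, and "the series" means these compounds.

Measured in an assay on isolated protein for inhibition of mitogen-activated protein kinase kinase kinase 14 (Homo sapiens), read by ADP-Glo, with a stated time of 60 min, tested at 100 uM, in the presence of a further agent that is not named here; a higher number here means more inhibition at the concentration tested (going by the name of the read-out), a lower number less inhibition:
Compound 1 `O=C(Nc1cc(C(F)(F)F)cc(C(F)(F)F)c1)c1nsnc1O`: 4.34%
Compound 2 `Cn1nnc(O)c1C(=O)Nc1cc(C(F)(F)F)cc(C(F)(F)F)c1`: 12.1%
Compound 3 `O=C(Nc1cc(C(F)(F)F)cc(C(F)(F)F)c1)c1nonc1O`: 19.3%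

Compound 3 stands highest of the three numbers: a number 15 percentage points higher from compound 1 to compound 3 (beyond the scatter), beyond the scatter, while a number 7.2 percentage points higher from compound 2 to compound 3 (within the scatter) lies within it. Compound 4 `Cc1c(C(=O)Nc2cc(C(F)(F)F)cc(C(F)(F)F)c2)c(O)nn1C` has not been measured. It differs from compound 3 by 3-hydroxy-1,5-dimethyl-1H-pyrazol-4-yl in place of 4-hydroxy-1,2,5-oxadiazol-3-yl on a carbonyl carbon. All three measured steps are swaps of this ring at the same carbonyl carbon, and they were small: a number 7.8 percentage points higher from compound 1 to compound 2 (within the scatter), a number 15 percentage points higher from compound 1 to compound 3 (beyond the scatter), a number 7.2 percentage points higher from compound 2 to compound 3 (within the scatter). Every measured number is low, so one more swap of this ring is expected to move the number little, if at all. Compound 4 is therefore estimated to give 12% in this assay, between 2% and 24%. The expected step is a number 7.3 percentage points lower from compound 3 to compound 4 (within the scatter).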

Compound 4, a percentage reported as inhibition, at one concentration (the size of the read-out at that concentration, not a potency): 24.1%
For compound 4 the middle estimate is 12.1 percentage points below the measured one; the whole stated range lies below it.
By their numbers in this assay, from the lowest: compounds 1, 2, 3 and 4 (each within the scatter of the next, the first and the last beyond it).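

Among the compounds shown here, the 3-hydroxy-1,5-dimethyl-1H-pyrazol-4-yl ring, the only one here with two ring hetero atoms, shows that this carbonyl carbon accepts a larger ring without loss in this assay and gives a number 19.8 percentage points higher from compound 1 to compound 4 (beyond the scatter) and also a number 12 percentage points higher from compound 2 to compound 4 (beyond the scatter) while the oxadiazole comparison gives a number 4.8 percentage points higher from compound 3 to compound 4 (within the scatter) and so leaves compound 3 and compound 4 unseparated. The data give no explanation for these steps. All four numbers remain low at the single concentration tested. As far as these compounds go, whether an amine or a carboxylic acid in place of the hydroxy group, or a longer chain in place of a methyl, would change this remains open.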